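The source may report more compounds than this note shows. Statements on the series, on what has been measured and on what is new or still open speak of the compounds shown alone.

Compound 3 `Cc1nc(N)sc1CCCN/C(N)=N/C(=O)NC(C)c1ccccc1F` gives 12.3 nM in a functional assay on Right cardiac atrium for agonist activity at histamine H2 receptor (Cavia porcellus), with a stated time of 30 min, in the presence of a further agent that is not named here (a lower number here means that less compound is needed, a higher number that more compound is needed for the effect), and stands lowest of the three numbers. Compound 1 `COc1ccc(C(C)NC(=O)/N=C(\N)NCCCc2sc(N)nc2C)cc1` gives 38 nM in this assay and compound 2 `Cc1nc(N)sc1CCCN/C(N)=N/C(=O)NC(C)c1ccc(Br)cc1` gives 55 nM. The step of a 1.4-fold higher number from compound 1 to compound 2 (0.16 log units; within the scatter) lies within the scatter, whereas a 3.1-fold lower number from compound 1 to compound 3 (0.49 log units; beyond the scatter) and a 4.5-fold lower number from compound 2 to compound 3 (0.65 log units; beyond the scatter) are modest steps beyond it.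

Compound 4 `Cc1nc(N)sc1CCCN/C(N)=N/C(=O)NC(C)c1ccc(Cl)cc1` differs from compound 3 by 4-chlorophenyl in place of 2-fluorophenyl on a saturated chain carbon bound to an amide-type nitrogen and a saturated chain carbon. Among the compounds with values here, the steps that bear on this change are the two into compound 3, a 3.1-fold lower number from compound 1 to compound 3 (0.49 log units; beyond the scatter) and a 4.5-fold lower number from compound 2 to compound 3 (0.65 log units; beyond the scatter), both of which replaced a 4-substituted phenyl with 2-fluorophenyl. Compound 1 with 4-methoxyphenyl and compound 2 with 4-bromophenyl give numbers within the scatter of each other, and 4-chlorophenyl is expected to fall in the same region, so a higher number than compound 3, of a size similar to those two steps, is expected for compound 4 in this assay. For compound 4 the estimate in this assay is 45 nM, with a range of 20 nM to 100 nM. The expected step is a 3.7-fold higher number from compound 3 to compound 4 (0.56 log units; beyond the scatter).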

Compound 4, half-maximal effective concentration: 24.6 nM
The estimate for compound 4 lay 1.8-fold (0.26 log units) above the measured number, within the range that was stated.
By their numbers in this assay, from the lowest: compounds 3, 4, 1 and 2 (each within the scatter of the next, the first and the last beyond it).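

In this assay, 4-chlorophenyl in place of 2-fluorophenyl gives a 2.0-fold higher number from compound 3 to compound 4 (0.30 log units; within the scatter), so on this saturated chain carbon a 4-substituted phenyl cannot be separated from 2-fluorophenyl in every case, as the steps from compound 1 and compound 2 into compound 3 alone might have suggested. The 4-substituted phenyls also no longer read as one group: chloro in place of bromo gives a 2.2-fold lower number from compound 2 to compound 4 (0.35 log units; beyond the scatter), a modest step, whereas chloro in place of methoxy gives a 1.5-fold lower number from compound 1 to compound 4 (0.19 log units; within the scatter). No measurement at hand gives a reason for these steps.

From the compounds shown here alone, it remains open how 4-fluorophenyl would compare with 4-chlorophenyl and 2-fluorophenyl on this carbon. Going by these compounds, a phenyl carrying an amine or a carboxylic acid on the aromatic carbon also remains untested against these halogens.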